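Sulfonanilide series: effect of removing the nitro group

This account rests on a few compounds, and the source may have more. Where it says the series, first, only, none or still open, it means among the compounds named here.

compound 2, `O=[N+]([O-])c1ccccc1NS(=O)(=O)c1ccccc1`: 14.8 nM
compound 1, `Cc1ccc(/N=C/c2ccccc2)cc1`: "not determined" (no result reported)

Among the compounds with values here, in a functional assay on LNCaP cells (Homo sapiens) for cytotoxicity, read by MTT assay, with a stated time of 5 days (on this read-out lower numbers stand for stronger inhibition of growth and higher numbers for weaker inhibition of growth), compound 2 gives 14.8 nM, the only number available in this assay; compound 1 gives "not determined" (no result reported). Compound 3 `O=S(=O)(Nc1ccccc1)c1ccccc1` differs from compound 2 in one place: hydrogen in place of nitro on an aromatic carbon. Within the data shown here, no pair of measured compounds differing in a single place exists, so no measured step size is known here. With the nitro leaving and only a hydrogen entering, a loss of growth inhibition beyond the usual scatter is expected, estimated as a 34-fold higher number from compound 2 to compound 3 (1.53 log units; beyond the scatter). Compound 3 is therefore expected to give about 500 nM in this assay, estimated within 50 nM to 5000 nM.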

Compound 3, concentration for 50% growth inhibition: 53500 nM
For compound 3 the middle estimate is 110-fold (2.03 log units) below the measured one; measured number above the stated range.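

In this assay, within the data shown here, hydrogen in place of nitro on an aromatic carbon, ortho to a large group, gives a 3600-fold higher number from compound 2 to compound 3 (3.56 log units; beyond the scatter) and is the first measured step. Growth inhibition in this pair therefore depends strongly on the nitro group at this place. Nothing measured here accounts for the size of the step.

As far as these compounds go, whether an amine or a nitrile on the same carbon would keep the growth inhibition of compound 2 remains open. So does the effect of a nitro group elsewhere on that ring.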